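Removing the terminal sugar from a naphthyl enone glucoside

The compounds below may be only part of what the source reports. "The series", "measured", "known", "first", "only" and "open" are said of these compounds alone.

Compound 1 `O=C(/C=C/c1ccccc1)C[C@@H]1O[C@H](CO)[C@@H](O[C@@H]2O[C@H](CO)[C@@H](O)[C@H](O)[C@H]2O)[C@H](O)[C@H]1O` gives -16.3% in an assay for inhibition of glucose-6-phosphatase catalytic subunit 1 (Rattus norvegicus), tested at 100 uM; a lower number here means less inhibition, a higher number more inhibition at the concentration tested (going by the name of the read-out). Compound 2 `CCOC(=O)C(C(=O)OCC)C(CC(=O)C[C@@H]1O[C@H](CO)[C@@H](O)[C@H](O)[C@H]1O)c1ccc(Cl)cc1` gives -6% in this assay. Compound 3 `O=C(/C=C/c1ccc2ccccc2c1)C[C@@H]1O[C@H](CO)[C@@H](O[C@@H]2O[C@H](CO)[C@@H](O)[C@H](O)[C@H]2O)[C@H](O)[C@H]1O` gives -3.9% in this assay.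

Compound 3 stands at the top of the three numbers, yet its gap to compound 2 lies within the scatter, while the step of a number 12.4 percentage points higher from compound 1 to compound 3 (beyond the scatter) lies beyond it. Compound 4 `O=C(/C=C/c1ccc2ccccc2c1)C[C@@H]1O[C@H](CO)[C@@H](O)[C@H](O)[C@H]1O` is not yet measured. It differs from compound 3 in one place: hydrogen in place of 3,4,5-trihydroxy-6-(hydroxymethyl)oxan-2-yl on an oxygen on a saturated carbon. Among the compounds with values here, no measured step follows this change; the only measured step, the one from compound 1 to compound 3, concerns the aromatic ring and not the sugar. Compound 2, which carries the single sugar only, and compound 3, which carries the double sugar, both sit near zero. The expectation for compound 4 is therefore a step of a number 0.1 percentage points lower from compound 3 to compound 4 (within the scatter), none beyond the scatter. Compound 4 is estimated at -4% in this assay, with a range from -18% to 10%.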

Compound 4, a percentage reported as inhibition, at one concentration (the size of the read-out at that concentration, not a potency): -7.7%
The estimate for compound 4 lay 3.7 percentage points above the measured number; low and high end bracket the measured number.
By their numbers in this assay, from the lowest: compounds 1, 4, 2 and 3 (each within the scatter of the next, the first and the last beyond it).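

The exchange of the 3,4,5-trihydroxy-6-(hydroxymethyl)oxan-2-yl group for hydrogen, on an oxygen on a saturated carbon, comes with a number 3.8 percentage points lower from compound 3 to compound 4 (within the scatter) in this assay. Within the data shown here, this is the first reading at this position, and it shows that, with the naphthalen-2-yl group kept, the outer sugar can be removed without a step beyond the scatter. The step does not bring inhibition into view, since compound 4 still gives -7.7% at the single concentration tested, and nothing available bears on what lies behind this reading.

The compounds shown leave open whether the same removal would read alike with phenyl in place of naphthalen-2-yl. They also leave open how a carboxylic acid in place of this hydroxy would read.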